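Butyl to propyl on the chain: toxicity notes

This account rests on a few compounds, and the source may have more. Where it says the series, first, only, none or still open, it means among the compounds named here.

Compound 1 `CCCCn1c(-c2ccc(OC)cc2)cnc1NC(=O)c1ccc(F)cc1` stands in a toxicity assay on THP-1 cells (Homo sapiens) for inhibition (on this read-out higher numbers stand for lower toxicity in this test and lower numbers for higher toxicity in this test), only at a limit, not a number: compound 1 gives > 100000 nM (the limit of > 100000 nM in this assay, at which 1 of the 2 values shown sits). Compound 2 `Cn1c(-c2ccccc2Cl)cnc1NC(=O)c1ccc(F)cc1` likewise sits at a limit, giving > 50000 nM in this assay. Compound 3 `CCCn1c(-c2ccc(OC)cc2)cnc1NC(=O)c1ccc(F)cc1` differs from compound 1 by hydrogen in place of methyl on a saturated chain carbon, three bonds along the chain from an aromatic nitrogen. Among the measured compounds shown here, no measured step between compounds is available, so no change beyond the usual scatter is expected in this assay for this shortening of the chain. Compound 3 is therefore expected to give 100000 nM, within a range of 30000 nM to 300000 nM. The step of a number no higher from compound 1 to compound 3 (the limit leaves the size open) is expected to be none beyond scatter.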

Compound 3, half-maximal cytotoxic concentration: > 100000 nM
Compound 3 gave a limit, no number; the forecaster's own chance of this, stated with the estimate: 85%; the middle value lies on the limit itself.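

Among the compounds shown here, compound 1 and compound 3 both stand at a limit, not a number, so no step between them can be read. The compounds shown leave open whether butyl to propyl changes toxicity at all.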